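Swapping a urea tail for benzyl on the amine nitrogen

The source may hold more compounds than are shown below. What is called first, only, known or untested is meant among the compounds shown, and "the series" means these compounds.

Measured so far:
compound 1, `CC(C)S(=O)(=O)NC(=O)c1ccc(Nc2nc(NC3(c4ccc(Cl)cc4)CC3)nc(OCC(F)(F)F)n2)cc1`: 96%
compound 2, `CC(C)NC(=O)NCCS(=O)(=O)NC(=O)c1ccc(Nc2nc(NC3(c4ccc(Cl)cc4)CC3)nc(OCC(F)(F)F)n2)cc1`: 97%

In an ADME assay on microsomes from liver (Rattus norvegicus) for metabolic stability, with a stated time of 10 min (on this read-out higher numbers stand for a more stable compound and lower numbers for a less stable compound), compound 1 gives 96%, and compound 2 gives 97%. Within the data shown here, compound 2 is the starting point here; its only measured neighbour is compound 1, and the step of a number 1 percentage points higher from compound 1 to compound 2 (within the scatter) lies within the scatter, so the two compounds cannot be told apart on this read-out.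

Compound 3, `O=C(NS(=O)(=O)CCNCc1ccccc1)c1ccc(Nc2nc(NC3(c4ccc(Cl)cc4)CC3)nc(OCC(F)(F)F)n2)cc1`, differs from compound 2 in one place: benzyl in place of isopropylcarbamoyl on an amine nitrogen. Among the measured compounds shown here, no measured step touches this spot. For the measured compounds named here, the single known step exchanged a group on the sulfonyl sulfur and was a number 1 percentage points higher from compound 1 to compound 2 (within the scatter), which says nothing about the exchange on the amine nitrogen. Both measured compounds sit near the top of the scale, leaving little room for a rise, while a fall cannot be ruled out from the data at hand. The expected step is therefore a number 12 percentage points lower from compound 2 to compound 3 (beyond the scatter). Compound 3 is estimated at 85%, with a range from 60% to 98%.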

Compound 3, percent of the compound remaining: 100%
For compound 3 the middle estimate is 15 percentage points below the measured one; the whole stated range lies below it.
By their numbers in this assay, from the lowest: compounds 1, 2 and 3 (each within the scatter of the next).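

In this assay, benzyl in place of isopropylcarbamoyl on the amine nitrogen gives a number 3 percentage points higher from compound 2 to compound 3 (within the scatter), so a six-membered aromatic ring of carbon only can stand where a chain with a carbonyl stood without a change that can be read. The full exchange on the sulfonyl sulfur, 2-(benzylamino)ethyl in place of isopropyl, gives a number 4 percentage points higher from compound 1 to compound 3 (within the scatter), which means that the plain isopropyl and both longer groups on that sulfur cannot be told apart on this read-out. Nothing available bears on why stability stays the same across these groups.

On these data alone, how the free amine, a carboxylic acid or a longer chain at this nitrogen would behave remains open. As far as these compounds go, with all three compounds near the top of the scale, it also remains open which groups here, if any, would give a clearly lower number.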